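The source may hold more compounds than are shown below. What is called first, only, known or untested is meant among the compounds shown, and "the series" means these compounds.

Measured in a functional assay on A549 cells (Homo sapiens) for antiproliferative activity, read by MTT assay, with a stated time of 24 h; on this read-out higher numbers stand for weaker inhibition and lower numbers for stronger inhibition:
Compound 1 `O=C(NNc1ccc(F)cc1)c1ccccc1NS(=O)(=O)c1cnc(O)nc1O`: > 20000 nM (a limit, not a number)
Compound 2 `CCCCOc1ccc(C(=O)NNC(=O)c2ccccc2NS(=O)(=O)c2cnc(O)nc2O)cc1`: 4960 nM

Only compound 2 has a true number, so it cannot be ranked against a series, and compound 2 stands at 4960 nM. Compound 1 gives only a limit of the assay, > 20000 nM, and the limit of > 20000 nM in this assay, at which 1 of the 2 values shown sits, marks that ceiling.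

Compound 3 `O=C(NNC(=O)c1ccccc1NS(=O)(=O)c1cnc(O)nc1O)c1cccc(Cl)c1` has 3-chlorophenyl in place of 4-butoxyphenyl on a carbonyl carbon. Within the data shown here, no measured pair shows what such a swap does in this assay, so any expectation here is loose. Among the measured compounds shown here, the only measured number, compound 2 at 4960 nM, is the anchor, and a moderate weakening seems the more likely direction. There is a real chance that the result for compound 3 is only a limit. The expected change is a 1.8-fold higher number from compound 2 to compound 3 (0.26 log units; within the scatter). For compound 3 the estimated value is 9000 nM, with an expected range from 3000 nM to 25000 nM.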

Compound 3, half-maximal inhibitory concentration: 1260 nM
Estimate against measurement, compound 3: 7.1-fold (0.85 log units) above; measured number below the stated range.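

In this assay, the group on this carbonyl carbon clearly matters: 3-chlorophenyl in place of 4-butoxyphenyl gives a 3.9-fold lower number from compound 2 to compound 3 (0.60 log units; beyond the scatter), so the bigger 4-butoxyphenyl, with its longer chain, is not needed for this level of activity. The swap of (3-chlorophenyl)carbonyl in place of 4-fluorophenyl on an amine nitrogen gives an at least 15-fold lower number from compound 1 to compound 3 (1.20 log units; beyond the scatter), which shows that this site also has a large effect on the read-out. That step rests on a limit of the assay for compound 1, so it gives a minimum size and not an exact one: the limit of > 20000 nM in this assay, at which 1 of the 3 values shown sits.

The data do not separate the loss of the butoxy chain from the arrival of chlorine, as both happen in one swap. As far as these compounds go, how a plain phenyl, an amine or a carboxylic acid would fare on the same carbonyl carbon also remains open.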